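From Ring-Nitrogen Hydrogen to 4-Ethylphenyl in a Proliferation Assay

The source may report more compounds than this note shows. Statements on the series, on what has been measured and on what is new or still open speak of the compounds shown alone.

Measured compounds:
compound 1 `CCCc1ccc(N2C(=O)NC3(CSC4=C3C(=O)c3ncccc3C4=O)C2=O)cc1`: 1 nM
compound 2 `O=C1NNC(=O)C2(CSC3=C2C(=O)c2ncccc2C3=O)N1`: 450 nM
compound 3 `O=C1NC(=O)C2(CSC3=C2C(=O)c2ncccc2C3=O)N1`: 120 nM

In a functional assay on CCRF-CEM cells (Homo sapiens) for antiproliferative activity, read by MTT assay, with a stated time of 96 h (a higher number here means a weaker inhibitor, a lower number a stronger inhibitor), compound 3 gives 120 nM, the second highest of the three numbers; compound 2 stands nearest with 450 nM, while compound 1 lies furthest at 1 nM. Compound 4 `CCc1ccc(N2C(=O)NC3(CSC4=C3C(=O)c3ncccc3C4=O)C2=O)cc1` is not yet measured. It differs from compound 3 by 4-ethylphenyl in place of hydrogen on an amide-type nitrogen in a ring. Among the compounds with values here, the one measured step that bears on this is a 120-fold higher number from compound 1 to compound 3 (2.08 log units; beyond the scatter), which removed a closely related aryl group from the same ring nitrogen and raised the number greatly. Putting an aryl group back is therefore expected to lower the number by a large step, a 60-fold lower number from compound 3 to compound 4 (1.78 log units; beyond the scatter), in this assay. Compound 4 is expected to give about 2 nM, within a range from 0.5 nM to 10 nM.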

Compound 4, half-maximal inhibitory concentration: 10 nM
For compound 4 the middle estimate is 5.0-fold (0.70 log units) below the measured one; measured number inside the range.
By their numbers in this assay, from the lowest: compound 1; then compound 4; then compound 3; then compound 2.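

In this assay the 4-ethylphenyl group on the ring nitrogen brings a 12-fold lower number from compound 3 to compound 4 (1.08 log units; beyond the scatter) so the gain from an aryl group here does not depend on the 4-propylphenyl of compound 1 alone. The far end of the chain also counts, since hydrogen in place of one methyl gives a 10-fold higher number from compound 1 to compound 4 (1.00 log units; beyond the scatter) and this position responds to a small edit. Nothing measured here explains either step.

Ethyl and propyl alone set no trend with chain length. Open, on these data alone, is whether a butyl chain would lower the number further, and how an amine or a carboxylic acid in place of the ethyl would fare.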